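Extending the chain end: from methoxy to piperidinyl

The source may report more compounds than this note shows. Statements on the series, on what has been measured and on what is new or still open speak of the compounds shown alone.

Compound 1 `Cn1ncc(Cl)c1-c1cc(C(=O)N[C@@H]2CN[C@H](CCO)C[C@H]2c2ccc(F)c(F)c2)oc1Cl`: 460 nM
Compound 2 `CC(=O)OCC[C@@H]1C[C@@H](c2ccc(F)c(F)c2)[C@H](NC(=O)c2cc(-c3c(Cl)cnn3C)c(Cl)o2)CN1`: 4960 nM
Compound 3 `COCC[C@@H]1C[C@@H](c2ccc(Cl)c(Cl)c2)[C@H](NC(=O)c2cc(-c3c(Cl)cnn3C)c(Cl)o2)CN1`: 1060 nM

Three compounds sharing one core were measured in a functional assay on OVCAR-8 cells (Homo sapiens) for antiproliferative activity; on this read-out lower numbers stand for stronger inhibition and higher numbers for weaker inhibition. Compound 1 gives 460 nM, compound 2 gives 4960 nM, and compound 3 gives 1060 nM. Compound 3 thus stands second highest of the three numbers, with compound 1 lower and compound 2 higher.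

Compound 4 `Cn1ncc(Cl)c1-c1cc(C(=O)N[C@@H]2CN[C@H](CCN3CCCCC3)C[C@H]2c2ccc(Cl)c(Cl)c2)oc1Cl` is not yet measured. It differs from compound 3 by piperidin-1-yl in place of methoxy on a saturated chain carbon, two bonds along the chain from a saturated ring carbon. Going by the values given here, the only measured step, an 11-fold higher number from compound 1 to compound 2 (1.03 log units; beyond the scatter), concerns the same chain end but a different replacement, acetyl for hydrogen on an oxygen; it shows that changes there can shift the read-out substantially. Among the compounds with values here, no step bears directly on piperidin-1-yl in place of methoxy, so the direction is open. Compound 4 is therefore estimated at 700 nM, with a wide range from 150 nM to 3500 nM, meaning an expected step of a 1.5-fold lower number from compound 3 to compound 4 (0.18 log units; within the scatter) in this assay.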

Compound 4, half-maximal inhibitory concentration: 1660 nM
Compound 4: middle estimate off by 2.4-fold (0.38 log units), on the low side, and the stated range covers the measured number.
By their numbers in this assay, from the lowest: compound 1; then compounds 3 and 4 (each within the scatter of the next); then compound 2.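

In this assay, piperidin-1-yl in place of methoxy gives a 1.6-fold higher number from compound 3 to compound 4 (0.19 log units; within the scatter), so this pair stays within the scatter even though a six-membered non-aromatic ring enters at the chain end. The acetyl replacement had given an 11-fold higher number from compound 1 to compound 2 (1.03 log units; beyond the scatter), so a change at this chain end does not always move the read-out beyond the scatter. No measurement shown here accounts for this outcome.

The compounds shown leave open how a primary amine, a morpholine ring, a carboxylic acid or a longer chain would read at this position. Compound 1 and compound 3 differ in more than one place, so the contribution of the hydroxyl end relative to the methoxy end cannot be read from them.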